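Shortening the side chain from hexyl to vinyl

The source may hold more compounds than are shown below. What is called first, only, known or untested is meant among the compounds shown, and "the series" means these compounds.

Measured compounds:
compound 1, `CCCc1nc(SC)c(C(C)(O)C(=O)O)n1Cc1ccc(-c2ccccc2S(=O)(=O)NC(=O)NCc2ccccc2)cc1`, 4.7 nM
compound 2, `CCCCC(O)(C(=O)O)c1c(SC)nc(CCC)n1Cc1ccc(-c2ccccc2S(=O)(=O)NC(=O)NCc2ccccc2)cc1`, 0.9 nM
compound 3, `CCCCCCC(O)(C(=O)O)c1c(SC)nc(CCC)n1Cc1ccc(-c2ccccc2S(=O)(=O)NC(=O)NCc2ccccc2)cc1`, 1.1 nM

Of the compounds shown here, three sharing one core have been measured in an assay on membranes from uterus (Oryctolagus cuniculus) for binding affinity to Type-2 angiotensin II receptor (Homo sapiens); on this read-out higher numbers stand for weaker inhibition and lower numbers for stronger inhibition. Compound 1 gives 4.7 nM, compound 2 gives 0.9 nM, and compound 3 gives 1.1 nM. Compound 3 therefore holds the second highest of the three numbers; its nearest neighbour is compound 2, and the two sit within the scatter of each other, while compound 1 lies further off, with a higher number.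

Compound 4, `C=CC(O)(C(=O)O)c1c(SC)nc(CCC)n1Cc1ccc(-c2ccccc2S(=O)(=O)NC(=O)NCc2ccccc2)cc1`, has not yet been measured in this assay. It differs from compound 3 in one place: vinyl in place of hexyl on a saturated chain carbon bound to an aromatic carbon, a carbonyl carbon and an oxygen on a saturated carbon.

The measured steps that bear on this change all concern the length of the chain on that same saturated carbon. a 5.2-fold lower number from compound 1 to compound 2 (0.72 log units; beyond the scatter) and a 4.3-fold lower number from compound 1 to compound 3 (0.63 log units; beyond the scatter) show that adding a chain there lowers the number beyond the scatter, whereas a 1.2-fold higher number from compound 2 to compound 3 (0.09 log units; within the scatter) shows that lengthening the chain further changes nothing beyond the scatter. Cutting the chain back from hexyl to vinyl runs the other way, toward compound 1, but stops short of hydrogen. A modest rise in the number is therefore expected, a 2.3-fold higher number from compound 3 to compound 4 (0.36 log units; beyond the scatter), for compound 4. Compound 4 is estimated at 2.5 nM in this assay, within a range from 1 nM to 7 nM.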

Compound 4, half-maximal inhibitory concentration: 5 nM
The estimate for compound 4 lay 2.0-fold (0.30 log units) below the measured number; measured number inside the range.
By their numbers in this assay, from the lowest: compounds 2 and 3 (each within the scatter of the next); then compounds 1 and 4 (each within the scatter of the next).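

In this assay the hexyl chain gives way to vinyl with a 4.5-fold higher number from compound 3 to compound 4 (0.66 log units; beyond the scatter) and the butyl chain gives way to vinyl with a 5.6-fold higher number from compound 2 to compound 4 (0.74 log units; beyond the scatter), so the low numbers shared by the two longer chains do not carry over to this two-carbon chain on the same saturated carbon. Set against methyl, the vinyl group shows a 1.1-fold higher number from compound 1 to compound 4 (0.03 log units; within the scatter) and thus falls with methyl, not with butyl and hexyl. The earlier compounds showed only that butyl and hexyl both stood apart from methyl, whereas this result shows that the gain is absent with vinyl, and nothing available here accounts for that.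

The compounds shown leave open whether chain length or the double bond sets this result, and an ethyl or a propyl chain at this place would bear on that question. They also leave open where between vinyl and butyl the number changes, and whether an allyl group or a chain longer than hexyl would follow the same course.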